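Extending a Chain on a Shared Core

The compounds below may be only part of what the source reports. "The series", "measured", "known", "first", "only" and "open" are said of these compounds alone.

Of the compounds shown here, three built on one shared core have been measured. In a functional assay, with a stated time of 16 h (a lower number here means a stronger inhibitor, a higher number a weaker inhibitor), compound 1 `CCC(CC)=NNc1nc(-c2cccc([N+](=O)[O-])c2)cs1` gives 1040000 nM, compound 2 `CCCC/C(C)=N\Nc1nc(-c2cccc([N+](=O)[O-])c2)cs1` gives 1060000 nM, and compound 3 `CCCC/C(CC)=N\Nc1nc(-c2cccc([N+](=O)[O-])c2)cs1` gives 1040000 nM. The cores of compound 1 and compound 2 differ by a group of 7 heavy atoms (6 carbon, 1 nitrogen; no ring) in place of a group of 6 heavy atoms (5 carbon, 1 nitrogen; no ring), on a nitrogen on an aromatic ring, with the step of a 1.0-fold higher number from compound 1 to compound 2 (0.01 log units; within the scatter). Compound 3 arises from compound 1 through (ethyl in place of hydrogen on a saturated chain carbon, two bonds along the chain from a carbon with a double bond to nitrogen), a change that made no change at the digits printed from compound 1 to compound 3 (within the scatter). The step of a 1.0-fold lower number from compound 2 to compound 3 (0.01 log units; within the scatter) is likewise small. Compound 4 `CCCCCC/C(C)=N\Nc1nc(-c2cccc([N+](=O)[O-])c2)cs1` is not yet measured; it arises from compound 2 through (ethyl in place of hydrogen on a saturated chain carbon, four bonds along the chain from a carbon with a double bond to nitrogen), the same kind of change as from compound 1 to compound 3, though here the place is four bonds rather than two bonds along the chain from a carbon with a double bond to nitrogen. Because the earlier step was no change at the digits printed from compound 1 to compound 3 (within the scatter), the expected step in this assay is a 1.0-fold lower number from compound 2 to compound 4 (0.00 log units; within the scatter). Compound 4 is therefore estimated at 1050000 nM, likely between 500000 nM and 2200000 nM.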

Compound 4, half-maximal inhibitory concentration: 1110000 nM
For compound 4 the middle estimate is 1.1-fold (0.02 log units) below the measured one; low and high end bracket the measured number.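

In this assay, ethyl in place of hydrogen on a saturated chain carbon, four bonds along the chain from a carbon with a double bond to nitrogen, gave a 1.0-fold higher number from compound 2 to compound 4 (0.02 log units; within the scatter) and so no shift beyond the scatter. Set beside the earlier step, the change reads alike on the two cores: the same change on two cores in this assay, no change at the digits printed (within the scatter) from compound 1 to compound 3 and a 1.0-fold higher number (0.02 log units; within the scatter) from compound 2 to compound 4, 1.0-fold (0.02 log units) apart, within the scatter of two such steps This shows that the change left the number within the scatter on both cores, at two different places on the chain, but with no step beyond the scatter it does not show how a change with a real effect would carry from one core to another.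

The compounds shown leave open whether anything other than a plain chain at this part of the molecule, such as an amine or a carboxylic acid, would move the number. They also leave open what a nitrile in place of the nitro group would do.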